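Chloro for methyl on the anilino ring of the series

A few compounds are considered here, and "the series" means these few. Any claim that something is new, unique, unknown or untested is made for them only; others in the source may bear on it.

Compound 3 `Cc1ccc(Nc2nc(C)c(C(=O)/C=C/c3ccc(Cl)cc3)s2)cc1` sits at the assay limit in a functional assay on Bel-7402 cells (Homo sapiens) for cytotoxicity, read by MTT assay (on this read-out lower numbers stand for stronger inhibition and higher numbers for weaker inhibition), giving > 25000 nM, a limit and not a number. Compound 1 `COc1ccc(/C=C/C(=O)c2sc(Nc3ccc(Cl)cc3)nc2C)cc1` likewise gives only the limit > 25000 nM in this assay. Compound 2 `COc1cccc(/C=C/C(=O)c2sc(Nc3ccc(Cl)cc3)nc2C)c1` also stops at the limit > 25000 nM in this assay. The step that the two limits leave unreadable from compound 1 to compound 2 thus cannot be read, and the limit of > 25000 nM in this assay, at which 3 of the 3 values shown sit, is all that the three values offer. Compound 4 `Cc1nc(Nc2ccc(Cl)cc2)sc1C(=O)/C=C/c1ccc(Cl)cc1` differs from compound 3 by chloro in place of methyl on an aromatic carbon, in words chloro in place of methyl on an aromatic carbon. Within the data shown here, no measured step bears on this change, and with every value at the limit no step beyond the scatter can be expected. The estimated step that the limit leaves unreadable from compound 3 to compound 4 is accordingly taken as flat. Compound 4 is therefore estimated at 30000 nM in this assay, within 10000 nM to 100000 nM, most likely again only a limit.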

Compound 4, half-maximal inhibitory concentration: > 25000 nM
Compound 4 gave a limit, no number; the forecaster's own chance of this, stated with the estimate: 80%; the middle value lies beyond the limit too.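

Among these compounds, no step from compound 1, compound 2 or compound 3 to compound 4 can be read, as all the values are limits and not numbers: the limit of > 25000 nM in this assay, at which 4 of the 4 values shown sit.
The compounds shown leave open which change, if any, would bring a readable value in this assay for this series.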